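Expectation for a 4-Cyanophenyl Analog of Compound 1

A few compounds are considered here, and "the series" means these few. Any claim that something is new, unique, unknown or untested is made for them only; others in the source may bear on it.

Of the compounds shown here, three built on one shared core have been measured in a functional assay (muscle tissue) with Cavia porcellus as the target; a higher number here means that more compound is needed for the effect, a lower number that less compound is needed. Compound 1, `COC(=O)C1=C(C)N=C(C)/C(=C(\O)OC)C1c1cccc(OC)c1`, gives 191 nM in this assay. Compound 2, `COC(=O)C1=C(C)N=C(C)/C(=C(\O)OC)C1c1ccccc1N`, gives 39800 nM, while compound 3, `COC(=O)C1=C(C)N=C(C)/C(=C(\O)OC)C1c1cccc(Br)c1`, gives 1.29 nM. Compound 1 therefore holds the second highest of the three numbers: the step of a 150-fold lower number from compound 1 to compound 3 (2.17 log units; beyond the scatter) is large, the step of a 210-fold higher number from compound 1 to compound 2 (2.32 log units; beyond the scatter) is large in the other direction, and the step of a 31000-fold lower number from compound 2 to compound 3 (4.49 log units; beyond the scatter) spans the whole set.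

Compound 4, `COC(=O)C1=C(C)N=C(C)/C(=C(\O)OC)C1c1ccc(C#N)cc1`, has not yet been measured in this assay. It differs from compound 1 by 4-cyanophenyl in place of 3-methoxyphenyl on a saturated ring carbon. Both measured steps that start from compound 1 exchange the aryl group on the same saturated ring carbon, and both moved this assay far beyond the scatter, so a large step is expected here as well. For the measured compounds named here, no measured compound carries a 4-cyanophenyl group, so the direction rests on the spread seen between compound 2 and compound 3; a higher number than compound 1 is expected. Compound 4 is estimated at 1500 nM, within 150 nM to 15000 nM. This corresponds to an expected step of a 7.9-fold higher number from compound 1 to compound 4 (0.90 log units; beyond the scatter).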

Compound 4, half-maximal effective concentration: 3470 nM
Beside the measured number, compound 4's estimate is 2.3-fold (0.36 log units) below it; the measured number falls inside the stated range.
By their numbers in this assay, from the lowest: compound 3; then compound 1; then compound 4; then compound 2.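

For the compounds shown here, compound 4 shows that this saturated ring carbon also allows an intermediate result in this assay, with an 18-fold higher number from compound 1 to compound 4 (1.26 log units; beyond the scatter) and an 11-fold lower number from compound 2 to compound 4 (1.06 log units; beyond the scatter) placing it inside the wide spread set by the earlier compounds. The 3-methoxyphenyl and 4-cyanophenyl groups match in their counts of heavy atoms, hydrogen-bond donors and hydrogen-bond acceptors, so the step from compound 1 to compound 4 shows that these matching counts do not keep the number in this assay within the scatter, while a 2700-fold higher number from compound 3 to compound 4 (3.43 log units; beyond the scatter) leaves the 3-bromophenyl group of compound 3 far apart from this new aryl group. No supporting evidence is available to explain this result.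

This change replaces both the substituent and its place on the phenyl ring, and the compounds shown cannot separate those two contributions. A plain phenyl group, or a nitrile and a bromo group each tested at the other's place on the ring, would be needed to tell how much of the spread belongs to the group itself and how much to where it sits.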